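Chain-end amine swap: compound 3 to compound 4

This account rests on a few compounds, and the source may have more. Where it says the series, first, only, none or still open, it means among the compounds named here.

Compound 3 `CN(C)CCCCn1c2c(c3ccccc31)C(=O)c1c[n+]([O-])c3ccccc3c1C2=O` gives 450 nM in a functional assay on HCT-116 cells (Homo sapiens) for cytotoxicity, read by MTT assay, with a stated time of 72 h; on this read-out higher numbers stand for weaker inhibition and lower numbers for stronger inhibition. Compound 2 `O=C1c2c[n+]([O-])c3ccccc3c2C(=O)c2c1c1ccccc1n2CCCCN1CCNCC1` gives 700 nM in this assay, and compound 1 `CN1CCN(CCCCCn2c3c(c4ccccc42)C(=O)c2c[n+]([O-])c4ccccc4c2C3=O)CC1` gives 1220 nM in this assay. Compound 3 carries the lowest of the three numbers; the nearest gap is a 1.6-fold lower number from compound 2 to compound 3 (0.19 log units; within the scatter) and is within the scatter, while the furthest is a 2.7-fold lower number from compound 1 to compound 3 (0.43 log units; beyond the scatter) and is beyond it.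

Compound 4 `CCCN1CCN(CCCCn2c3c(c4ccccc42)C(=O)c2c[n+]([O-])c4ccccc4c2C3=O)CC1` differs from compound 3 by 4-propylpiperazin-1-yl in place of dimethylamino on a saturated chain carbon, four bonds along the chain from an aromatic nitrogen. The two measured steps that bear on this both run the opposite way, from a piperazine terminus to dimethylamino: piperazin-1-yl to dimethylamino gave the within-scatter step above, and (4-methylpiperazin-1-yl)methyl to dimethylamino gave the modest step beyond it. Returning from dimethylamino to a piperazine, here 4-propylpiperazin-1-yl, is therefore expected to raise the number in this assay by about a 1.8-fold higher number from compound 3 to compound 4 (0.25 log units; within the scatter). Compound 4 is estimated at 800 nM in this assay, with a range from 400 nM to 1600 nM.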

Compound 4, half-maximal inhibitory concentration: 790 nM
Compound 4: the middle estimate sits 1.0-fold (0.01 log units) above what was measured; measured number inside the range.
By their numbers in this assay, from the lowest: compounds 3, 2, 4 and 1 (each within the scatter of the next, the first and the last beyond it).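

Propyl in place of hydrogen on the ring amine nitrogen gives a 1.1-fold higher number from compound 2 to compound 4 (0.05 log units; within the scatter) in this assay, so this substitution on the piperazine terminus produces no change that can be read. The exchange of dimethylamino, with 3 heavy atoms, for 4-propylpiperazin-1-yl, with 9 heavy atoms, gives a 1.8-fold higher number from compound 3 to compound 4 (0.24 log units; within the scatter), so this much larger terminus is accommodated at the chain end without a step beyond the scatter. The remaining comparison gives a 1.5-fold lower number from compound 1 to compound 4 (0.19 log units; within the scatter), which places compound 4 within the scatter of compound 1 as well as of compound 2 and compound 3.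

No measurement available here explains these steps. Going by these compounds, whether a morpholine or a primary amine at the chain end would move the number beyond the scatter remains open, as does the effect of a longer chain carrying the dimethylamino group.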